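A few compounds are considered here, and "the series" means these few. Any claim that something is new, unique, unknown or untested is made for them only; others in the source may bear on it.

Of the compounds shown here, three have been tested in a functional assay on NCI-H23 cells (Homo sapiens) for cytotoxicity, read by sulforhodamine B assay, with a stated time of 48 h; on this read-out lower numbers stand for stronger inhibition of growth and higher numbers for weaker inhibition of growth. Compound 1 `Nc1nc(Cl)c2ncn(Cc3ccccc3CCl)c2n1` gives 3020 nM, compound 2 `ClCc1cccc(Cn2cnc3nc(Cl)nc(Cl)c32)c1` gives 1540 nM, and compound 3 `ClCc1ccc(Cn2cnc3ncnc(Cl)c32)cc1` gives 15800 nM. Compound 2 stands at the lowest of the three numbers; compound 1 lies within the scatter of it, while compound 3 lies beyond the scatter, at a clearly higher number.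

The next compound, compound 4 `ClCc1cccc(Cn2cnc3ncnc(Cl)c32)c1`, is derived from compound 2 by a single change: hydrogen in place of chloro on an aromatic carbon. Compound 2 carries two chloro groups on its core; compound 4 keeps only one.

For the measured compounds named here, no measured pair shows this exact change, so its size must be estimated. Compound 3 also carries a single chloro on its core and gives 15800 nM, a weaker result than compound 2, which suggests that removing the chloro costs activity. The step of a 5.2-fold higher number from compound 2 to compound 4 (0.72 log units; beyond the scatter) is therefore expected to go toward weaker growth inhibition. Compound 4 is estimated at 8000 nM, with a likely range from 3000 nM to 25000 nM.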

Compound 4, concentration for 50% growth inhibition: 1230 nM
The estimate for compound 4 lay 6.5-fold (0.81 log units) above the measured number; measured number outside the range, below it.
By their numbers in this assay, from the lowest: compounds 4, 2 and 1 (each within the scatter of the next, the first and the last beyond it); then compound 3.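

In this assay the chloro on the aromatic carbon between two ring nitrogen atoms can give way to hydrogen with no real effect: a 1.3-fold lower number from compound 2 to compound 4 (0.10 log units; within the scatter). For the compounds shown here, until now no two compounds differed at this one place, so this is the first direct reading of that change. Compound 3 at 15800 nM lacks this chloro as well, and so does compound 4 at 1230 nM, so its absence alone does not set compound 3 apart, and nothing at hand explains why the change leaves the number in place.

From the compounds shown here alone, whether a methyl group, a methoxy group or a fluoro group on this same carbon would also leave the number in place remains open. Also open, going by these compounds, is what hydrogen in place of the remaining chloro of compound 4 would give.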